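Swapping methoxy for ethynyl on the pyridine ring

This account rests on a few compounds, and the source may have more. Where it says the series, first, only, none or still open, it means among the compounds named here.

Compound 1, `COc1ccccc1C#Cc1csc(C)n1`, gives 36.3 nM in a functional assay on CHO cells for agonist activity at metabotropic glutamate receptor 5 (Homo sapiens), read by inositol phosphate accumulation; a higher number here means a weaker inhibitor, a lower number a stronger inhibitor. Compound 2, `COc1ccc(C#Cc2csc(C)n2)cn1`, gives 426 nM in this assay. Compound 3, `OCC#Cc1nc(C#Cc2cccc(F)c2)cs1`, gives only a limit in this assay, > 10000 nM.

Among the two compounds with a number, compound 2 stands at the higher one; its number is higher than that of compound 1, and that difference is beyond the usual scatter. Compound 3 sits at the assay limit (the limit of > 10000 nM in this assay, at which 1 of the 3 values shown sits), so its value is a boundary and not a number.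

Compound 4, `C#Cc1ccc(C#Cc2csc(C)n2)cn1`, has not yet been measured. It differs from compound 2 in one place: ethynyl in place of methoxy on an aromatic carbon. Among the compounds with values here, no pair of measured compounds shows the effect of this exact swap, so its direction is open. The ethynyl group keeps the count of heavy atoms the same, so a step of only moderate size is expected, possibly none beyond the scatter. Compound 4 is estimated at 500 nM in this assay, within 120 nM to 2500 nM, a step of a 1.2-fold higher number from compound 2 to compound 4 (0.07 log units; within the scatter) that is expected rather than known.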

Compound 4, half-maximal inhibitory concentration: 2950 nM
Compound 4: the middle estimate sits 5.9-fold (0.77 log units) below what was measured, and the stated range ends below it.
By their numbers in this assay, from the lowest: compound 1; then compound 2; then compound 4. At a limit, above all of these: compound 3.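

Within the data shown here, this swap is the first measured change at this place, on an aromatic carbon next to the ring nitrogen, and it gives a 6.9-fold higher number from compound 2 to compound 4 (0.84 log units; beyond the scatter) in this assay, so ethynyl in place of methoxy weakens inhibition in this pair. The two groups have the same count of heavy atoms, so a matching count does not guarantee a matching result, though the hydrogen-bond acceptor of the methoxy group leaves with it. Nothing measured here ties the step to any one difference between the two groups.

The compounds shown leave open how other groups would behave at this carbon, such as an amine, a chlorine atom or a longer chain like ethoxy. Among these compounds, whether the step holds on another core also stays open, as this single pair is the only example of the swap.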